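A Methyl in Place of a Cyclobutylcarbonyl, Starting from Limits

The source may hold more compounds than are shown below. What is called first, only, known or untested is meant among the compounds shown, and "the series" means these compounds.

Measured compounds:
compound 1, `Cc1[nH]nc(N)c1-c1ccc(Cl)c(Cl)c1` — in an assay on Sf9 cells for inhibition of mitogen-activated protein kinase kinase kinase 14 (Homo sapiens), read by ADP-Glo, with a stated time of 60 min (a lower number here means a stronger inhibitor, a higher number a weaker inhibitor), compound 1 gives > 100000 nM, a limit of the assay.
compound 2, `Cc1c(-c2ccc(Cl)c(Cl)c2)c(N)nn1C(=O)C1CCC1` — in this assay compound 2 gives > 100000 nM, also a limit.

Within the data shown here, compound 2 therefore stands only at a limit, and the one other value in the set is a limit as well. Among the measured compounds shown here, the single measured step, a step that the two limits leave unreadable from compound 1 to compound 2, cannot be read in size or direction because both values sit at the limit of > 100000 nM in this assay, at which 2 of the 2 values shown sit. Nothing in the measured pair shows whether a group on the aromatic nitrogen moves the number at all.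

Compound 3, `Cc1c(-c2ccc(Cl)c(Cl)c2)c(N)nn1C`, differs from compound 2 by methyl in place of cyclobutylcarbonyl on an aromatic nitrogen. For the measured compounds named here, no measured step bears readably on this change; the only step available is the unreadable one just described. The expectation can therefore rest on nothing more than the two limits. Compound 3 is expected to give about 100000 nM in this assay, with a likely range from 30000 nM to 300000 nM. The step this estimate implies is expected to be a number no higher from compound 2 to compound 3 (the limit leaves the size open), with the most probable outcome a limit rather than a number.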

Compound 3, half-maximal inhibitory concentration: > 100000 nM
Compound 3 ended at the assay's limit (the forecaster's own chance of this, stated with the estimate: 80%); the middle value sits exactly at the limit.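

Among these compounds, no step among compound 1, compound 2 and compound 3 can be read, in size or in direction, because all three values are limits and not numbers: the limit of > 100000 nM in this assay, at which 3 of the 3 values shown sit. The compounds shown leave open whether hydrogen, methyl or cyclobutylcarbonyl on the aromatic nitrogen makes any difference in this assay at all.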